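A few compounds are considered here, and "the series" means these few. Any claim that something is new, unique, unknown or untested is made for them only; others in the source may bear on it.

Compound 1 `Cn1c(-c2ccc(NC(=O)CCl)cc2)nc(-c2ccccc2)c1-c1ccccc1`: 53.2%
Compound 2 `Cc1ccc2oc(SCC(=O)Nc3ccc(-c4nc(-c5ccccc5)c(-c5ccccc5)n4C)cc3)nc2c1`: 59.5%
Compound 3 `Cn1nnnc1SCC(=O)Nc1ccc(-c2nc(-c3ccccc3)c(-c3ccccc3)n2C)cc1`: 84%

These values come from a functional assay on HT-29 cells (Homo sapiens) for cytotoxicity, read by MTT assay, with a stated time of 24 h, tested at 32 ug/mL; on this read-out higher numbers stand for a stronger effect at the one concentration tested and lower numbers for a weaker effect. Compound 3 stands highest of the three, with compound 2 nearest and compound 1 furthest, both gaps beyond the scatter. Compound 4 `Cc1nnc(SCC(=O)Nc2ccc(-c3nc(-c4ccccc4)c(-c4ccccc4)n3C)cc2)s1` is not yet measured and differs from compound 3 in one place: 5-methyl-1,3,4-thiadiazol-2-yl in place of 1-methyl-1H-tetrazol-5-yl on a sulfur. The step that bears on this change is the earlier exchange of a ring on that same sulfur, a number 24.5 percentage points higher from compound 2 to compound 3 (beyond the scatter), while a number 6.3 percentage points higher from compound 1 to compound 2 (within the scatter) stayed within the scatter. Compound 4 keeps a five-membered aromatic ring on the sulfur, as compound 3 does, so only a small decrease, or none beyond the scatter, is expected in this assay. The estimate for compound 4 is 72%, with a range from 50% to 90%, meaning an expected step of a number 12 percentage points lower from compound 3 to compound 4 (beyond the scatter).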

Compound 4, a percentage reported as activity, at one concentration (the size of the read-out at that concentration, not a potency): 87.1%
Compound 4: middle estimate off by 15.1 percentage points, on the low side; measured number inside the range.
By their numbers in this assay, from the lowest: compounds 1 and 2 (each within the scatter of the next); then compounds 3 and 4 (each within the scatter of the next).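

In this assay, replacing the 1-methyl-1H-tetrazol-5-yl on the sulfur with 5-methyl-1,3,4-thiadiazol-2-yl leaves the number within the scatter (a number 3.1 percentage points higher from compound 3 to compound 4 (within the scatter)), so two different five-membered aromatic rings give a similar result here. The high number therefore does not depend on the tetrazole alone, as compound 4 also stands clear of the benzoxazole (a number 27.6 percentage points higher from compound 2 to compound 4 (beyond the scatter)) and of the chloro compound (a number 33.9 percentage points higher from compound 1 to compound 4 (beyond the scatter)). No measurement shown explains this similarity.

Going by these compounds, it remains open how a six-membered ring such as pyridine, or a simple amine, would behave in this place. On these data alone, the effect of a longer chain between the sulfur and the carbonyl also remains open.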